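This account rests on a few compounds, and the source may have more. Where it says the series, first, only, none or still open, it means among the compounds named here.

Working notes on the series. Three measured compounds share one core and differ only in the substituted phenyl on the sulfonyl sulfur. Compound 1 `Cc1ccc2ncc(S(=O)(=O)c3ccc(Cl)c(Cl)c3)c(N3CCC(C)CC3)c2c1` carries the 3,4-dichlorophenyl; in an assay on isolated protein for displacement of a labelled ligand from metabotropic glutamate receptor 5 (Homo sapiens), with a stated time of 60 min, tested at 1 uM (a lower number here means less inhibition, a higher number more inhibition at the concentration tested (going by the name of the read-out)), compound 1 gives 82%. Compound 2 `Cc1ccc2ncc(S(=O)(=O)c3ccc(C)c(C)c3)c(N3CCC(C)CC3)c2c1` carries the 3,4-dimethylphenyl, and in this assay compound 2 gives 90%. Compound 3 `Cc1ccc2ncc(S(=O)(=O)c3ccc(C)c(Cl)c3)c(N3CCC(C)CC3)c2c1` carries the 3-chloro-4-methylphenyl; in this assay compound 3 gives 91%, the highest of the three numbers, though its gaps to the other two are within the scatter.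

Among the measured compounds shown here, the steps so far: a number 8 percentage points higher from compound 1 to compound 2 (within the scatter), a number 9 percentage points higher from compound 1 to compound 3 (within the scatter), and a number 1 percentage points higher from compound 2 to compound 3 (within the scatter). Every swap of chloro and methyl on this ring has stayed within the scatter.

Compound 4 `Cc1ccc2ncc(S(=O)(=O)c3ccc(C)c(F)c3)c(N3CCC(C)CC3)c2c1` is not yet measured. The change from compound 3 is fluoro in place of chloro on an aromatic carbon. The three steps above bear on it, since each exchanges one small substituent on the same sulfonyl-bound ring, and none moved the read-out beyond the scatter. A further exchange of one halogen for another at this carbon is therefore expected to give no step beyond the scatter in this assay, the expected step being a number 3 percentage points lower from compound 3 to compound 4 (within the scatter). Compound 4 is estimated at 88% in this assay, with a range from 78% to 96%.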

Compound 4, a percentage reported as inhibition, at one concentration (the size of the read-out at that concentration, not a potency): 91%
Beside the measured number, compound 4's estimate is 3 percentage points below it, within the range that was stated.
By their numbers in this assay, from the lowest: compounds 1, 2, 3 and 4 (each within the scatter of the next).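

Fluoro on this aromatic carbon, ortho to a methyl group, behaves in this assay as chloro and methyl do there: the halogen exchange gives no change at the digits printed from compound 3 to compound 4 (within the scatter), and fluoro in place of methyl gives a number 1 percentage points higher from compound 2 to compound 4 (within the scatter). The wider exchange of 3,4-dichlorophenyl for 3-fluoro-4-methylphenyl on the sulfonyl sulfur gives a number 9 percentage points higher from compound 1 to compound 4 (within the scatter), so fluoro extends to a third substituent the finding that exchanges at this carbon stay within the scatter, and all four compounds remain unranked in this read-out. No measurement shown here offers an explanation for this flat result.

On these data alone, a read-out at a single concentration is not a potency, so whether the four compounds differ in potency stays open. Also open is how this assay would respond to a group of a different kind at this carbon, such as an amine, a carboxylic acid or a longer chain, none of which appears among the compounds shown.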